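From a propyl chain to a 4-(diethylamino)butyl chain

A few compounds are considered here, and "the series" means these few. Any claim that something is new, unique, unknown or untested is made for them only; others in the source may bear on it.

Measured in a functional assay on cells (Homo sapiens) for antiproliferative activity, read by MTT assay, with a stated time of 48 h (on this read-out higher numbers stand for weaker inhibition and lower numbers for stronger inhibition), where a sign marks a limit and not a number:
Compound 1 `Cn1c(N)c(-c2nc3ccccc3[nH]2)c2nc(C#N)c(C#N)nc21`: > 50000 nM, a limit
Compound 2 `CCCn1c(N)c(-c2nc3ccccc3[nH]2)c2nc(C#N)c(C#N)nc21`: > 50000 nM, a limit
Compound 3 `N#Cc1nc2c(-c3nc4ccccc4[nH]3)c(N)n(CCCN3CCCCC3)c2nc1C#N`: 6230 nM

Compound 2 has no number to start from, since its > 50000 nM is only a limit. Compound 1 also stands at a limit, with > 50000 nM. Compound 4 `CCN(CC)CCCCn1c(N)c(-c2nc3ccccc3[nH]2)c2nc(C#N)c(C#N)nc21` has not yet been measured. The change leading to it is (diethylamino)methyl in place of hydrogen on a saturated chain carbon, three bonds along the chain from an aromatic nitrogen. Cut one bond further out, the same difference reads propyl to 4-(diethylamino)butyl.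

The closest measured step is an at least 8.0-fold lower number from compound 2 to compound 3 (0.90 log units; beyond the scatter), which puts piperidin-1-yl at the same place on the chain. A second step, an at least 8.0-fold lower number from compound 1 to compound 3 (0.90 log units; beyond the scatter), points the same way. The remaining one, a step that the two limits leave unreadable from compound 1 to compound 2, adds nothing on size. Both readable steps start from limits, so their true size may be larger.

A step towards a lower number, beyond the scatter, is therefore expected in this assay, resting on compound 3 with its 6230 nM. The estimated step is an at least 7.1-fold lower number from compound 2 to compound 4 (0.85 log units; beyond the scatter). For compound 4 the expected value is 7000 nM, with an estimated range from 2500 nM to 25000 nM.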

Compound 4, half-maximal inhibitory concentration: 640 nM
Beside the measured number, compound 4's estimate is 11-fold (1.04 log units) above it; the measured number lies below the stated range.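

In this assay, the change of piperidin-1-yl to (diethylamino)methyl, on a saturated chain carbon three bonds along the chain from an aromatic nitrogen, gives a 9.7-fold lower number from compound 3 to compound 4 (0.99 log units; beyond the scatter), so the amine-bearing chains shown are not equal and this position still has room to move beyond what compound 3 revealed. Against the chains that carry no amine, the change now reaches a large size, with an at least 78-fold lower number from compound 2 to compound 4 (1.89 log units; beyond the scatter) and an at least 78-fold lower number from compound 1 to compound 4 (1.89 log units; beyond the scatter). Compound 1 and compound 2 each stand at a limit, so these two sizes are bounded from one side only: the limit of > 50000 nM in this assay, at which 2 of the 4 values shown sit.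

Compound 4 differs from compound 3 in the amine and in the length of the chain together, and the compounds shown do not tell these two apart; a 4-(piperidin-1-yl)butyl chain or a 3-(diethylamino)propyl chain on the shared core would do so. Also open, going by these compounds, is whether the amine nitrogen itself is needed, since no chain of this length ending in a hydroxyl group or an amide stands among them, and whether a longer chain would go further still.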